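The source may report more compounds than this note shows. Statements on the series, on what has been measured and on what is new or still open speak of the compounds shown alone.

Compound 1, `N#CCNC(=O)[C@@H]1CC(F)(F)C[C@H]1C(=O)N1CCOCC1`, gives 925 nM in a functional assay on A20 cells (Mus musculus) for inhibition, with stated times of 1 h, 16 h and 24 h; a lower number here means a stronger inhibitor, a higher number a weaker inhibitor.
Compound 2, `N#CC1(NC(=O)[C@@H]2C[C@@H](S(=O)(=O)c3ccccc3)C[C@H]2C(=O)N2CCOCC2)CCC1`, gives 236 nM in this assay.
Compound 3, `N#CC1(NC(=O)[C@@H]2C[C@@H](S(=O)(=O)c3ccccc3)C[C@H]2C(=O)N2CCCCC2)CC1`, gives 5 nM in this assay.

Among these three, compound 3 has the lowest number in this assay, and its gaps to compound 2 and to compound 1 both lie beyond the scatter, so it is the strongest inhibitor of the three. Compound 4, `N#CC1(NC(=O)[C@@H]2C[C@@H](S(=O)(=O)c3ccccc3)C[C@H]2C(=O)N2CC(O)C2)CC1`, has not yet been measured. It differs from compound 3 in one place: 3-hydroxyazetidin-1-yl in place of piperidin-1-yl on a carbonyl carbon. Among the compounds with values here, no pair of measured compounds differs by this change alone, so there is no measured step to lean on. The measured compounds show that changes around the shared core can move the number a great deal, but they do not show the direction for this particular change. A loss of potency of moderate size is expected, and the step is estimated at an 8.0-fold higher number from compound 3 to compound 4 (0.90 log units; beyond the scatter). Compound 4 is therefore expected to give about 40 nM in this assay, within a range from 8 nM to 200 nM.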

Compound 4, half-maximal inhibitory concentration: 572 nM
Beside the measured number, compound 4's estimate is 14-fold (1.16 log units) below it; the measured number lies above the stated range.
By their numbers in this assay, from the lowest: compound 3; then compound 2; then compounds 4 and 1 (each within the scatter of the next).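

Replacing piperidin-1-yl with 3-hydroxyazetidin-1-yl on the carbonyl carbon gives a 110-fold higher number from compound 3 to compound 4 (2.06 log units; beyond the scatter) in this assay, a large loss of inhibition that shows how strongly the outcome depends on the group at this place. As the only step shown that changes one place alone, it supplies the direction the earlier compounds could not: here, the six-membered ring without a hydrogen-bond donor is far better than the four-membered ring with one. Nothing available explains why the number rises so far. From the compounds shown here alone, the step changes ring size and adds a hydroxyl group together, so the share of each remains open. A plain azetidine ring and a piperidine ring carrying a hydroxyl group would each isolate one of these two changes.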